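The source may report more compounds than this note shows. Statements on the series, on what has been measured and on what is new or still open speak of the compounds shown alone.

Measured compounds in a toxicity assay on Vero cells (Chlorocebus sabaeus) for cytotoxicity; on this read-out higher numbers stand for lower toxicity in this test and lower numbers for higher toxicity in this test:
Compound 1, `COc1nc(C2CCOCC2)ccc1[C@@H](c1ccccc1)[C@@](O)(CCN(C)C)c1cccc2ccccc12`, gives > 50 ug/mL, which is a limit of the assay rather than a number.
Compound 2, `COc1nc(-c2ccc(F)cc2)ccc1[C@@H](c1ccccc1)[C@@](O)(CCN(C)C)c1cccc2ccccc12`, gives > 50 ug/mL, again a limit of the assay.
Compound 3, `COc1ccc(-c2ccc([C@@H](c3ccccc3)[C@@](O)(CCN(C)C)c3cccc4ccccc34)c(OC)n2)cc1`, gives > 50 ug/mL, also a limit of the assay.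

In this assay every value recorded so far sits at the same point, (the limit of > 50 ug/mL in this assay, at which 3 of the 3 values shown sit). Compound 3 therefore stands at this limit, alongside the other two, and no ordering among the three can be read. The steps a step that the two limits leave unreadable from compound 1 to compound 2, a step that the two limits leave unreadable from compound 1 to compound 3 and a step that the two limits leave unreadable from compound 2 to compound 3 are all unreadable for the same reason: both ends of each step are limits.

Compound 4, `COc1nc(-c2ccccc2Cl)ccc1[C@@H](c1ccccc1)[C@@](O)(CCN(C)C)c1cccc2ccccc12`, has not yet been measured. 2-chlorophenyl in place of 4-methoxyphenyl on an aromatic carbon The step most like this one, from compound 2 to compound 3, also exchanged one group on the attached phenyl ring for another, and it too could not be sized. With every measured step unreadable and every value at the limit, no step beyond the scatter is expected in this assay, and a step that the limit leaves unreadable from compound 3 to compound 4 is the expected step. Compound 4 is thus estimated at 60 ug/mL, within a range of 25 ug/mL to 150 ug/mL, most likely reported again as a limit.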

Compound 4, half-maximal cytotoxic concentration: > 50 ug/mL
Compound 4: only a limit was reported; the forecaster's own chance of this, stated with the estimate: 75%; the middle value lies beyond the limit too.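

In this assay compound 4 gives > 50 ug/mL, which is a limit of the assay, so its steps from compound 1, compound 2 and compound 3 cannot be read: the limit of > 50 ug/mL in this assay, at which 4 of the 4 values shown sit.

The compounds shown leave open how far apart these four truly lie, and whether any group at this place would give a readable number.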